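The source may hold more compounds than are shown below. What is called first, only, known or untested is meant among the compounds shown, and "the series" means these compounds.

Among the measured compounds shown here, in a functional assay on MCF7 cells (Homo sapiens) for inhibition, read by sulforhodamine B assay, with a stated time of 48 h (on this read-out lower numbers stand for stronger inhibition of growth and higher numbers for weaker inhibition of growth), compound 1 (`c1cc(NC2=NCCO2)cc(OC2CCCC2)c1`) gives 62100 nM and compound 2 (`c1ccc(Oc2cccc(NC3=NCCO3)c2)cc1`) gives 12200 nM, the lower of the two numbers so far. Compound 3 (`O=C(CCl)NC(=O)Nc1cccc(Oc2ccccc2)c1`) keeps the phenyl on oxygen of compound 2 and changes the group on the nitrogen on an aromatic ring: a group of 7 heavy atoms (3 carbon, 1 nitrogen, 2 oxygen, 1 chlorine; no ring) in place of a group of 5 heavy atoms (3 carbon, 1 nitrogen, 1 oxygen; one five-membered non-aromatic ring with 2 hetero atoms), on a nitrogen on an aromatic ring. For the measured compounds named here, the only measured step, a 5.1-fold lower number from compound 1 to compound 2 (0.71 log units; beyond the scatter), is a modest one at the oxygen, with phenyl in place of cyclopentyl. Going by the values given here, no step at the nitrogen has been measured, so that step offers only a rough guide to size and does not set a direction. In this assay, a modest change is therefore expected, tentatively toward a lower number. The estimated change is a 1.5-fold lower number from compound 2 to compound 3 (0.18 log units; within the scatter). Compound 3 is expected at 8000 nM, with an estimated range of 2500 nM to 28000 nM.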

Compound 3, concentration for 50% growth inhibition: 8100 nM
Compound 3: middle estimate off by 1.0-fold (0.01 log units), on the low side, and the stated range covers the measured number.
By their numbers in this assay, from the lowest: compounds 3 and 2 (each within the scatter of the next); then compound 1.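

In this assay, among the compounds shown here, the first step at the nitrogen on an aromatic ring is small (a 1.5-fold lower number from compound 2 to compound 3 (0.18 log units; within the scatter)), and it lies within the scatter. For the compounds shown here, with the phenyl on oxygen kept, the open-chain ((chloromethyl)carbonyl)carbamoyl group and the five-membered non-aromatic ring with 2 hetero atoms cannot be told apart on this read-out, so this ring is not needed to hold the level of compound 2, whereas the earlier step showed only that the group on the oxygen matters. No supporting data bear on why these two different groups read alike.

Still open, from the compounds shown here alone, is which part of the new group counts, for instance whether a methyl or a bromomethyl in place of the chloromethyl holds the same level. Also open, going by these compounds, is whether a simple amine or a longer chain on that nitrogen reads alike, and whether cyclopentyl on the oxygen gives the same step alongside the new group.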